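A few compounds are considered here, and "the series" means these few. Any claim that something is new, unique, unknown or untested is made for them only; others in the source may bear on it.

In an assay on isolated protein for inhibition of DNA topoisomerase 1 (Homo sapiens), with a stated time of 30 min, tested at 100 uM (a higher number here means a stronger effect of the compound at the concentration tested, a lower number a weaker effect), compound 2 `Oc1cccc(-c2cc(-c3ccccc3)nc(-c3ccccc3)c2)c1` gives 11.5%. Among the compounds with values here, the only other compound measured so far is compound 1 `Oc1ccc(-c2cc(-c3ccccc3)cc(-c3ccsc3)n2)cc1`, which in this assay gives 20.4%; the two numbers lie within the usual scatter of each other, so neither can be called the stronger. Compound 3 `Oc1cccc(-c2cc(-c3ccccc3)nc(-c3cccs3)c2)c1` has not yet been measured. It differs from compound 2 in one place: thiophen-2-yl in place of phenyl on an aromatic carbon. Within the data shown here, no measured pair shows what this change does, so in this assay a step of no size beyond the scatter is expected, in either direction. Compound 3 is expected to give 15%, likely between 4% and 30%. That expectation means a step of a number 3.5 percentage points higher from compound 2 to compound 3 (within the scatter).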

Compound 3, a percentage reported as inhibition, at one concentration (the size of the read-out at that concentration, not a potency): 9.1%
Estimate against measurement, compound 3: 5.9 percentage points above; measured number inside the range.
By their numbers in this assay, from the lowest: compounds 3, 2 and 1 (each within the scatter of the next, the first and the last beyond it).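

Placing thiophen-2-yl in place of phenyl on this aromatic carbon, next to the ring nitrogen, gives a number 2.4 percentage points lower from compound 2 to compound 3 (within the scatter) in this assay. Within the data shown here, this is the first measured pair for the change, and it shows that a five-membered ring with one sulfur can replace the six-membered carbon ring here without a step beyond the scatter. Nothing measured explains this result. Going by these compounds, it remains open whether an amine, a carboxylic acid or a longer chain on this carbon would move the number beyond the scatter.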